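This account rests on a few compounds, and the source may have more. Where it says the series, first, only, none or still open, it means among the compounds named here.

Working notes on the series. Compound 1 is `CC(C)N(Cc1cccc(OCCCCCC(=O)O)c1)C(=O)c1ccc(-c2ccco2)cc1`. In an ADME assay on BJ cells (Homo sapiens) for cytotoxicity, read by CellTiter-Glo and resazurin assay, with a stated time of 72 h (a higher number here means that more compound is needed for the effect, a lower number that less compound is needed), compound 1 gives > 26000 nM, which is a limit of the assay and not a number. Compound 2 is `CC(C)N(Cc1cccc(OCCCCCC(=O)O)c1)C(=O)c1ccc(-c2cccc([N+](=O)[O-])c2)cc1`, with 3-nitrophenyl in place of furan-2-yl on an aromatic carbon. In this assay compound 2 gives > 26000 nM, again a limit. Compound 3 is `CCOC(=O)CCCCCOc1cccc(CN(C(=O)c2ccc(-c3ccco3)cc2)C(C)C)c1`, with ethyl in place of hydrogen on an oxygen next to a carbonyl group. In this assay compound 3 gives > 26000 nM, also a limit, so compound 3 stands at the same limit as the rest of the series.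

The two measured steps, a step that the two limits leave unreadable from compound 1 to compound 2 and a step that the two limits leave unreadable from compound 1 to compound 3, cannot be sized because of the limit of > 26000 nM in this assay, at which 3 of the 3 values shown sit. Neither the aryl swap nor the ester formation has moved anything out of the unreadable range.

Compound 4 is `CCOC(=O)CCCCCOc1cccc(CN(C(=O)c2ccc(-c3cccc(Br)c3)cc2)C(C)C)c1`. It differs from compound 3 by 3-bromophenyl in place of furan-2-yl on an aromatic carbon. Going by the values given here, the only comparable aryl change, from compound 1 to compound 2, stayed at the limit, so no step beyond the scatter can be read from the data, and the expectation is that compound 4 also sits at the limit. The step of a number no higher from compound 3 to compound 4 (the limit leaves the size open) is therefore expected to be essentially flat. Compound 4 is estimated at 26000 nM, with a range of 10000 nM to 70000 nM.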

Compound 4, half-maximal effective concentration: > 26000 nM
Compound 4: no number, only a limit (the forecaster's own chance of this, stated with the estimate: 85%); the middle value sits exactly at the limit.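

Compound 3 and compound 4 both stand at a limit of the assay and not at a number, so no step can be read between them: the limit of > 26000 nM in this assay, at which 4 of the 4 values shown sit.

The compounds shown leave open the concentration at which any of them reaches the effect in this assay and whether any change in the series alters it.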